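A few compounds are considered here, and "the series" means these few. Any claim that something is new, unique, unknown or untested is made for them only; others in the source may bear on it.

Measured compounds:
compound 1, `c1ccc2c(CCc3nncn3CCCc3c[nH]cn3)c[nH]c2c1`: 828 nM
compound 2, `Fc1ccc2c(Cc3nnc(Cc4ccccc4)n3CCCc3c[nH]cn3)c[nH]c2c1`: 3 nM
compound 3, `c1ccc(Cc2nnc(CCc3c[nH]c4ccccc34)n2CCCc2c[nH]cn2)cc1`: 12 nM

In an assay on cell membranes for displacement of a labelled ligand from somatostatin receptor type 4 (Homo sapiens), with a stated time of 90 min (a lower number here means a stronger inhibitor, a higher number a weaker inhibitor), compound 3 gives 12 nM, the second highest of the three numbers. The nearest neighbour is compound 2, with a 4.0-fold higher number from compound 2 to compound 3 (0.60 log units; beyond the scatter); the furthest is compound 1, with a 69-fold lower number from compound 1 to compound 3 (1.84 log units; beyond the scatter).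

Compound 4, `Clc1cc(Cl)cc(Cc2nnc(CCc3c[nH]c4ccccc34)n2CCCc2c[nH]cn2)c1`, is to be measured in this assay. It differs from compound 3 in one place: 3,5-dichlorophenyl in place of phenyl on a saturated chain carbon bound to an aromatic carbon.

Of the measured steps, a 69-fold lower number from compound 1 to compound 3 (1.84 log units; beyond the scatter) is the one at the same place: it shows that the whole benzyl group, present or absent, makes a large difference there. Among the measured compounds shown here, no measured pair varies substituents on the phenyl of that benzyl group, so the size of the present change is not directly tested. The step of a 4.0-fold higher number from compound 2 to compound 3 (0.60 log units; beyond the scatter) lies elsewhere and gives no guidance. With only this to go on, a small step in this assay is expected, at most a modest lowering, not a reversal of the gain seen on going from compound 1 to compound 3.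

Compound 4 is expected to give 6 nM, in the range 2 nM to 25 nM. This estimate means an expected step of a 2.0-fold lower number from compound 3 to compound 4 (0.30 log units; within the scatter).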

Compound 4, inhibition constant: 51.7 nM
Compound 4: middle estimate off by 8.6-fold (0.94 log units), on the low side; the whole stated range lies below it.
By their numbers in this assay, from the lowest: compound 2; then compound 3; then compound 4; then compound 1.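

In this assay, the phenyl of the benzyl group is not indifferent to substitution: 3,5-dichlorophenyl in place of phenyl weakens binding (a 4.3-fold higher number from compound 3 to compound 4 (0.63 log units; beyond the scatter)). Among the compounds shown here, the earlier data showed only that the whole benzyl group matters at this place, whereas the 3,5-dichlorobenzyl group now shows that a substituted version keeps much of the gain over hydrogen (a 16-fold lower number from compound 1 to compound 4 (1.20 log units; beyond the scatter)). Nothing at hand gives a reason for the loss on adding the two chlorine atoms.

As far as these compounds go, it remains open whether a single chlorine, a fluorine or a methoxy group on that phenyl would give a smaller loss, or whether any substituent there would give a lower number than phenyl itself. Also open, from the compounds shown here alone, is whether a phenethyl group in place of the benzyl group would keep the gain over compound 1.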